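The source may hold more compounds than are shown below. What is called first, only, known or untested is meant among the compounds shown, and "the series" means these compounds.

Measured so far in an assay on cells for inhibition of Amine oxidase [flavin-containing] B (Homo sapiens), read by fluorescence and Amplex Red, using microsomes, with a stated time of 15 min; on this read-out higher numbers stand for weaker inhibition and lower numbers for stronger inhibition:
- compound 1 `COc1ccc2occ(C(=O)Nc3ccccc3)c(=O)c2c1` gives 41.8 nM
- compound 2 `COc1ccc2occ(C(=O)Nc3cccc(Cl)c3)c(=O)c2c1` gives 3.94 nM

Compound 2 stands lowest of the two numbers in this assay, the step of an 11-fold lower number from compound 1 to compound 2 (1.03 log units; beyond the scatter) being the only measured one in the series. Compound 3 `COc1ccc2occ(C(=O)Nc3cccc(O)c3)c(=O)c2c1` carries the change (hydroxy in place of chloro on an aromatic carbon). Going by the values given here, no measured step involves a hydroxy group, so the step from compound 1 to compound 2 bears on it only by showing how much the chloro group is worth. Compound 3 is expected to move back toward the number of compound 1, by a 5.1-fold higher number from compound 2 to compound 3 (0.71 log units; beyond the scatter). The estimate for compound 3 in this assay is 20 nM, within 5 nM to 80 nM.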

Compound 3, half-maximal inhibitory concentration: 114 nM
The estimate for compound 3 lay 5.7-fold (0.76 log units) below the measured number, and the stated range ends below it.
By their numbers in this assay, from the lowest: compound 2; then compound 1; then compound 3.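

In this assay, hydroxy in place of chloro costs more than chloro gained, with a 29-fold higher number from compound 2 to compound 3 (1.46 log units; beyond the scatter) on this carbon of the anilide ring. Hydroxy does not simply return the series to the unsubstituted compound either, with a 2.7-fold higher number from compound 1 to compound 3 (0.44 log units; beyond the scatter) in the same read-out, so at this position one substituent lowers the number and another raises it. Nothing at hand explains why these two groups part in this way.

Still open, going by these compounds, is how an amine or a methoxy group on this carbon would read, and whether fluoro or bromo would keep the gain seen with chloro.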